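The source may report more compounds than this note shows. Statements on the series, on what has been measured and on what is new or still open speak of the compounds shown alone.

Measured in an ADME assay (liver) for pharmacokinetics, with Liver microsome (Rattus norvegicus) as the target, read by LC-MS, using microsomes, tested at 2 uM; on this read-out higher numbers stand for fast clearance and lower numbers for slow clearance:
- compound 1 `O=C(N[C@@H]1CCCC[C@H]1O)c1cnc(OCC2CC2)c(-c2ccc(Cl)cc2)c1`: 0.064 mL/min/kg
- compound 2 `O=C(N[C@@H]1CCCC[C@H]1O)c1cnc(OCc2ccncc2)c(-c2ccc(Cl)cc2)c1`: 0.118 mL/min/kg
- compound 3 `O=C(N[C@@H]1CCCC[C@H]1O)c1cnc(OCc2cccnc2)c(-c2ccc(Cl)cc2)c1`: 0.374 mL/min/kg

Compound 1 has the smallest number of the three, but the data do not separate it from its nearest neighbour, with a 1.8-fold higher number from compound 1 to compound 2 (0.27 log units; within the scatter). The furthest compound is clearly apart, with a 5.8-fold higher number from compound 1 to compound 3 (0.77 log units; beyond the scatter). The two pyridinyl compounds also differ, with a 3.2-fold higher number from compound 2 to compound 3 (0.50 log units; beyond the scatter).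

Compound 4 `C[C@](O)(CNC(=O)c1cnc(OCC2CC2)c(-c2ccc(Cl)cc2)c1)C1CC1` keeps the core of compound 1 and changes only the group on the amide-type nitrogen: a group of 7 heavy atoms (6 carbon, 1 oxygen; one three-membered non-aromatic ring of carbon only) in place of a group of 7 heavy atoms (6 carbon, 1 oxygen; one six-membered non-aromatic ring of carbon only), on an amide-type nitrogen. The 2-hydroxycyclohexyl group leaves, and a group holding a three-membered non-aromatic ring of carbon only enters.

For the measured compounds named here, none of the measured steps touches this place. All three alter the group on a saturated chain carbon bound to an oxygen on an aromatic ring, so they show only how far this assay has moved within this small set. They give no direct evidence for the new change, and its direction remains uncertain. A small rise is expected, possibly within the scatter, and a step larger than a 5.8-fold higher number from compound 1 to compound 3 (0.77 log units; beyond the scatter) is not expected. The expected change is a 1.6-fold higher number from compound 1 to compound 4 (0.19 log units; within the scatter). For compound 4 the estimated value is 0.1 mL/min/kg, with an expected range from 0.035 mL/min/kg to 0.3 mL/min/kg.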

Compound 4, clearance: 0.0024 mL/min/kg
Compound 4: middle estimate off by 42-fold (1.62 log units), on the high side, outside the stated range (below it).
By their numbers in this assay, from the lowest: compound 4; then compounds 1 and 2 (each within the scatter of the next); then compound 3.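

The group on the amide-type nitrogen proves to be a place where this assay responds strongly: replacing the 2-hydroxycyclohexyl group gives a 27-fold lower number from compound 1 to compound 4 (1.43 log units; beyond the scatter) with the rest of compound 1 unchanged, a larger step than any seen among compound 1, compound 2 and compound 3 at the saturated chain carbon. The counts do not tell the two groups apart in heavy atoms, hydrogen-bond donors, hydrogen-bond acceptors or net charge, so the computed differences are the ring, three-membered in place of six-membered, and the number of defined stereocentres. Nothing available accounts for the size or direction of this step.

The compounds leave open which part of the entering group goes with the step, as the ring and the surrounding chain change together, and whether a plain cyclohexyl group, a longer chain or an amine on the amide-type nitrogen would read in the same way. They also leave open whether the entering group would give a similar step alongside the pyridin-4-yl group of compound 2 or the pyridin-3-yl group of compound 3.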